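Thiosemicarbazone aryl swap: estimating compound 4's cytotoxicity

The source may hold more compounds than are shown below. What is called first, only, known or untested is meant among the compounds shown, and "the series" means these compounds.

Measured compounds:
Compound 1 `COc1ccc(/C=N\NC(=S)NC(C)(C)CCC[C@](C)(O)[C@@H]2CC=C(C)CC2)cc1`: 7420 nM
Compound 2 `CC1=CC[C@@H]([C@@](C)(O)CCCC(C)(C)NC(=S)N/N=C\c2ccc(N(C)C)cc2)CC1`: 27700 nM
Compound 3 `CC1=CC[C@@H]([C@@](C)(O)CCCC(C)(C)NC(=S)N/N=C\c2cccc([N+](=O)[O-])c2)CC1`: 14100 nM

All three were tested in a functional assay on HT-29 cells (Homo sapiens) for cytotoxicity, read by sulforhodamine B assay; a lower number here means a stronger inhibitor of growth, a higher number a weaker inhibitor of growth. Compound 1 gives the lowest number of the three; its nearest neighbour is compound 3, whose value lies within the scatter of compound 1, while compound 2 sits further off, as the step of a 3.7-fold higher number from compound 1 to compound 2 (0.57 log units; beyond the scatter) shows. The step of a 1.9-fold higher number from compound 1 to compound 3 (0.28 log units; within the scatter) is within the scatter, as is a 2.0-fold lower number from compound 2 to compound 3 (0.29 log units; within the scatter).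

Compound 4 `CC1=CC[C@@H]([C@@](C)(O)CCCC(C)(C)NC(=S)N/N=C(/C)c2ccccc2)CC1` is not yet measured. It differs from compound 1 by a group of 9 heavy atoms (8 carbon, 1 nitrogen; one six-membered aromatic ring of carbon only) in place of a group of 10 heavy atoms (8 carbon, 1 nitrogen, 1 oxygen; one six-membered aromatic ring of carbon only), on an amide-type nitrogen: the methoxy group is gone, and a methyl group now sits on the carbon with the double bond to nitrogen. Going by the values given here, no measured step covers exactly this change. Among the compounds with values here, the steps that bear on it are those that alter the aromatic part of compound 1, namely a 3.7-fold higher number from compound 1 to compound 2 (0.57 log units; beyond the scatter) and a 1.9-fold higher number from compound 1 to compound 3 (0.28 log units; within the scatter); both moved the number upward, one beyond the scatter and one within it. A modest upward step is therefore expected, with a 1.5-fold higher number from compound 1 to compound 4 (0.17 log units; within the scatter). The estimate for compound 4 in this assay is 11000 nM, within a range from 4000 nM to 30000 nM.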

Compound 4, concentration for 50% growth inhibition: 28400 nM
The estimate for compound 4 lay 2.6-fold (0.41 log units) below the measured number; low and high end bracket the measured number.
By their numbers in this assay, from the lowest: compounds 1, 3, 2 and 4 (each within the scatter of the next, the first and the last beyond it).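

Compound 4 carries a methyl group on the carbon with a double bond to nitrogen and has no methoxy group, and in this assay this combined change gives a 3.8-fold higher number from compound 1 to compound 4 (0.58 log units; beyond the scatter). Going by these compounds alone, the earlier steps altered only the group on the aromatic ring, so this is the first sign that a change that also reaches that carbon can raise the number beyond the scatter, and the step is not a small one to overlook. No measurement here explains the rise in the number.

How much of the step belongs to the lost methoxy group and how much to the added methyl group stays open, as the compounds shown do not separate the two. Also open, as far as these compounds go, is how an ethyl group on that carbon, or a chlorine on the aromatic ring, would read in this assay.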